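Fluoro on the benzyl group of compound 1

The source may hold more compounds than are shown below. What is called first, only, known or untested is meant among the compounds shown, and "the series" means these compounds.

In a functional assay on HeLa cells (Homo sapiens) for antiproliferative activity, read by MTT assay, with a stated time of 48 h (a lower number here means a stronger inhibitor, a higher number a weaker inhibitor), compound 1 (`Cc1c(Cc2ccccc2)c(=O)oc2cc(OCCOc3no[n+]([O-])c3S(=O)(=O)c3ccccc3)ccc12`) gives 22.9 nM and stands at the low end of the three measured numbers, level with one neighbour and far from the other. Compound 2 (`COc1cc(OCCOc2no[n+]([O-])c2S(=O)(=O)c2ccccc2)ccc1C(=O)/C=C/c1ccccc1`) gives 17.8 nM in the same read-out, which lies within the scatter of compound 1. Compound 3 (`COCCOc1no[n+]([O-])c1S(=O)(=O)c1ccccc1`) gives 8830 nM and has none of the benzyl-bearing portion of compound 1, and its number is higher than that of compound 1 by far more than the scatter.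

The next member, compound 4 (`Cc1c(Cc2ccc(F)cc2)c(=O)oc2cc(OCCOc3no[n+]([O-])c3S(=O)(=O)c3ccccc3)ccc12`), differs from compound 1 in one place: fluoro in place of hydrogen on an aromatic carbon (fluoro in place of hydrogen on an aromatic carbon, para to a large group, so benzyl to 4-fluorobenzyl). Within the data shown here, no measured pair in this set shows this change or any other single change, so the data offer no direct guide to its size. With nothing to favour a direction, the anchor in this assay is compound 1 at 22.9 nM alone. The estimated step of a 1.1-fold lower number from compound 1 to compound 4 (0.06 log units; within the scatter) is expected to stay within the scatter. For compound 4 the expected value of 20 nM comes with an estimated range from 9 nM to 45 nM in this series.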

Compound 4, half-maximal inhibitory concentration: 2.8 nM
The estimate for compound 4 lay 7.1-fold (0.85 log units) above the measured number; the whole stated range lies above it.
By their numbers in this assay, from the lowest: compound 4; then compounds 2 and 1 (each within the scatter of the next); then compound 3.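

In this assay the benzyl group of compound 1 proves to be a responsive position: the change from benzyl to 4-fluorobenzyl gives an 8.2-fold lower number from compound 1 to compound 4 (0.91 log units; beyond the scatter), so a single fluoro on an aromatic carbon, para to a large group, is enough to move the number beyond the scatter. Among these compounds, the earlier compounds formed no pair differing in one place, so they gave no reading of this position or of any other single change, and this step is the first such reading. No measurement shown here bears on what lies behind the step, which rests on one pair of compounds.

Still open, on these data alone, is whether the step belongs to fluoro itself or would also appear with chloro, methoxy or trifluoromethyl at the same carbon, and whether fluoro on another carbon of this ring would give a similar step. Also open, as far as these compounds go, is how this position responds to a charged or hydrogen-bonding group such as an amine or a carboxylic acid, and whether a longer chain in place of the benzyl methylene link would keep the step.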